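From 3,5-dimethoxybenzyl to allyl in compound 4

This account rests on a few compounds, and the source may have more. Where it says the series, first, only, none or still open, it means among the compounds named here.

In a functional assay on MCF7 cells (Homo sapiens) for inhibition, read by sulforhodamine B assay, with a stated time of 48 h (on this read-out higher numbers stand for weaker inhibition and lower numbers for stronger inhibition), compound 1 (`COc1ccc(C(c2ccc(OCCO)cc2)c2cccc3ccccc23)c(OC)c1OC`) gives > 20000 nM, which is a limit and not a number. Compound 2 (`COc1ccc(C(c2ccc(O)cc2)c2cccc3ccccc23)c(OC)c1OC`) gives 17500 nM. Compound 3 (`COc1cc(COC(c2ccc(OC)c(OC)c2OC)c2cccc3ccccc23)cc(OC)c1`) gives > 20000 nM, which is also a limit and not a number. Compound 3 therefore has no measured number of its own, and the series is marked by the limit of > 20000 nM in this assay, at which 2 of the 3 values shown sit.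

Compound 4 (`C=CCOC(c1ccc(OC)c(OC)c1OC)c1cccc2ccccc12`) differs from compound 3 by vinyl in place of 3,5-dimethoxyphenyl on a saturated chain carbon bound to an oxygen on a saturated carbon. For the measured compounds named here, no measured step covers this change. The nearest is an at least 1.1-fold lower number from compound 1 to compound 2 (0.05 log units; that floor lies within the scatter), which involves a different substituent, and its floor lies within the scatter. It gives no direction for the change at hand, so no step beyond the scatter is expected in this assay. The expected result is a number no higher from compound 3 to compound 4 (the limit leaves the size open), and a further limit reading would be no surprise. For compound 4 the estimated value is 20000 nM, with an expected range from 9000 nM to 40000 nM.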

Compound 4, half-maximal inhibitory concentration: > 20000 nM
Compound 4: no number, only a limit; the forecaster's own chance of this, stated with the estimate: 65%; the middle value sits exactly at the limit.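

In this assay compound 4 gives > 20000 nM, which is a limit and not a number, so the change from 3,5-dimethoxybenzyl to allyl at this place yields no measurable value. The steps from compound 3 to compound 4 and from compound 1 to compound 4 cannot be read, as both ends of each are limits. The one readable step is an at least 1.1-fold higher number from compound 2 to compound 4 (0.05 log units; that floor lies within the scatter), and with allyl in place of the aromatic 3,5-dimethoxybenzyl the series stays at the same edge of the read-out: the limit of > 20000 nM in this assay, at which 3 of the 4 values shown sit.

On these data alone, whether any group on this saturated chain carbon gives a value clear of the limit remains open. An amine, a carboxylic acid or a longer chain in place of allyl could settle that, and the compounds shown give no reading for any of them.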